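This account rests on a few compounds, and the source may have more. Where it says the series, first, only, none or still open, it means among the compounds named here.

Among the compounds with values here, in a functional assay on A549 cells (Homo sapiens) for antiproliferative activity, read by MTT assay, with a stated time of 72 h (on this read-out lower numbers stand for stronger inhibition and higher numbers for weaker inhibition), compound 1 (`COc1ccc(-c2ncnn2-c2cc(OC)c(OC)c(OC)c2)cc1`) gives 520 nM as the only actual number so far. Compound 2 (`COc1cc(-c2ncnn2-c2ccc(N)cc2)cc(OC)c1OC`) is recorded as > 10000 nM in this test, and that entry is a limit of the assay, not a number. Compound 3 (`COc1cc(-n2ncnc2-c2ccccc2)cc(OC)c1OC`) has not yet been measured. It departs from compound 1 at a single place, hydrogen in place of methoxy on an aromatic carbon in all, with hydrogen in place of methoxy on an aromatic carbon, para to a large group, so that 4-methoxyphenyl becomes phenyl. Within the data shown here, no measured pair shows this change directly, so the expectation starts from compound 1 at 520 nM and points towards weaker inhibition, by a moderate margin beyond the scatter. The expected move is a 5.8-fold higher number from compound 1 to compound 3 (0.76 log units; beyond the scatter) in this assay overall. For compound 3 the estimate is 3000 nM with an expected range of 700 nM to 12000 nM in this test.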

Compound 3, half-maximal inhibitory concentration: > 10000 nM
Compound 3 was reported as a limit; the forecaster's own chance of this, stated with the estimate: 20%; at least 3.3-fold (0.52 log units) between middle value and limit.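

In this assay, the methoxy on an aromatic carbon para to a large group proves to matter for compound 1: replacing it with hydrogen, so that 4-methoxyphenyl becomes phenyl, gives an at least 19-fold higher number from compound 1 to compound 3 (1.28 log units; beyond the scatter). Within the data shown here, this is the first comparison of compounds differing in one place, and it ties the measurable activity of compound 1 to this single methoxy. How far the loss extends stays unread, because compound 3 is recorded only as a limit: the limit of > 10000 nM in this assay, at which 2 of the 3 values shown sit.

The compounds shown leave open whether a hydroxyl, a chlorine atom or an ethoxy group at this place would keep the activity of compound 1. They also leave open whether the oxygen alone would suffice or the methyl carbon is needed too.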